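This account rests on a few compounds, and the source may have more. Where it says the series, first, only, none or still open, it means among the compounds named here.

Going by the values given here, compound 3 `CC(=O)OC/C(=C\C1CCCCC1)C(=O)c1ccc(Cl)cc1` stands at the top of the three numbers measured so far: in a functional assay on WiDr cells (Homo sapiens) for inhibition, read by sulforhodamine B assay, with a stated time of 48 h (on this read-out higher numbers stand for weaker inhibition of growth and lower numbers for stronger inhibition of growth), compound 3 gives 21000 nM, level with compound 1 `CC(=O)OC/C(=C\C1CCCCC1)C(=O)c1ccccc1`, which gives 21000 nM, while compound 2 `O=C(OC/C(=C\C1CCCCC1)C(=O)c1ccccc1)c1ccccc1` gives 19000 nM. The two steps recorded, a 1.1-fold lower number from compound 1 to compound 2 (0.04 log units; within the scatter) and no change at the digits printed from compound 1 to compound 3 (within the scatter), both lie within the scatter, so the shared core of these three compounds has so far tolerated changes at the ester end and at the benzoyl ring without any shift in this assay.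

Compound 4 `CC(=O)OC/C(=C\c1ccc(Cl)cc1Cl)C(=O)c1ccc(Cl)cc1` differs from compound 3 by 2,4-dichlorophenyl in place of cyclohexyl on a double-bonded chain carbon bound to a double-bonded chain carbon. Neither measured step touches this part of the molecule; the ester change and the aromatic chloro both left this assay unmoved, but they give no direct guide to swapping a saturated ring for an aromatic one on the chain. The expected step of a 1.1-fold lower number from compound 3 to compound 4 (0.02 log units; within the scatter) is therefore set at none beyond the scatter, with a wide margin. Compound 4 is estimated at 20000 nM, within 5000 nM to 60000 nM.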

Compound 4, concentration for 50% growth inhibition: 8100 nM
Beside the measured number, compound 4's estimate is 2.5-fold (0.39 log units) above it, within the range that was stated.
By their numbers in this assay, from the lowest: compound 4; then compounds 2, 1 and 3 (each within the scatter of the next).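

Putting 2,4-dichlorophenyl in place of cyclohexyl on a double-bonded chain carbon bound to a double-bonded chain carbon gives the first step beyond the scatter among these compounds: in this assay it is a modest strengthening of growth inhibition (a 2.6-fold lower number from compound 3 to compound 4 (0.41 log units; beyond the scatter)). The earlier changes, phenyl for methyl and chloro for hydrogen on an aromatic carbon, left the number unmoved, so this is the one place shown where a change registers. Nothing measured here accounts for the shift.

With the ring and its two chlorines entering together, the compounds shown leave open how much of the step belongs to the aromatic ring and how much to the chlorines. They also leave open how this position would respond to a ring bearing an amine or a carboxylic acid, or to a longer chain in place of the ring.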